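The source may report more compounds than this note shows. Statements on the series, on what has been measured and on what is new or still open speak of the compounds shown alone.

Among the measured compounds shown here, compound 1, `COc1cc(/C=C/C(=O)c2cccc(NC(=O)c3c(Cl)cccc3Cl)c2)ccc1O`, is the stronger of the two compounds measured so far. In a functional assay on SiHa cells (Homo sapiens) for inhibition (a lower number here means a stronger inhibitor, a higher number a weaker inhibitor), compound 1 gives 3.56 ug/mL, the lowest of the two numbers. Compound 2, `COc1cc(/C=C/C(=O)c2cccc(N)c2)ccc1O`, carries only a hydrogen where compound 1 carries the (2,6-dichlorophenyl)carbonyl group on the nitrogen on the aromatic ring; in this assay compound 2 gives 12.3 ug/mL, a step of a 3.5-fold higher number from compound 1 to compound 2 (0.54 log units; beyond the scatter), so taking the whole acyl group away weakens inhibition modestly.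

Compound 3, `CCOC(=O)C(=O)Nc1cccc(C(=O)/C=C/c2ccc(O)c(OC)c2)c1`, keeps the acyl group on that nitrogen but changes what sits on the carbonyl carbon: ethoxycarbonyl in place of 2,6-dichlorophenyl on a carbonyl carbon. For the measured compounds named here, the only measured step that bears on this is the one from compound 1 to compound 2, which shows that the (2,6-dichlorophenyl)carbonyl group contributes something, but not much; replacing the 2,6-dichlorophenyl part with ethoxycarbonyl while keeping the carbonyl is expected to cost a smaller share of that contribution. Compound 3 is therefore expected to give a somewhat higher number, a step of about a 2.0-fold higher number from compound 1 to compound 3 (0.29 log units; within the scatter), with an estimate of 7 ug/mL, most likely between 3.5 ug/mL and 14 ug/mL.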

Compound 3, half-maximal inhibitory concentration: > 50 ug/mL
Compound 3: a limit, no number; the forecaster's own chance of this, stated with the estimate: 5%; middle value at least 7.1-fold (0.85 log units) from the limit.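

In this assay compound 3 gives > 50 ug/mL, which is a limit and not a number: the limit of > 50 ug/mL in this assay, at which 1 of the 3 values shown sits. Putting ethoxycarbonyl in place of 2,6-dichlorophenyl on the carbonyl carbon gives an at least 14-fold higher number from compound 1 to compound 3 (1.14 log units; beyond the scatter), so keeping a carbonyl on the nitrogen is not enough to hold inhibition, and what sits on that carbon matters far more than the earlier pair could show. Placing (ethoxycarbonyl)carbonyl on the nitrogen instead of hydrogen gives an at least 4.0-fold higher number from compound 2 to compound 3 (0.60 log units; beyond the scatter), the opposite direction to the step that adding (2,6-dichlorophenyl)carbonyl makes, so acylating this nitrogen can either strengthen or weaken inhibition, depending on the acyl group.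

The compounds shown leave open whether the loss comes from removing the 2,6-dichlorophenyl or from introducing the ethoxycarbonyl, as this single swap does both at once. A phenyl without chlorine, a methyl or a carboxylic acid on that carbonyl carbon would help separate these two readings, and a true number for compound 3 would still be needed to give the full size of its steps.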